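A few compounds are considered here, and "the series" means these few. Any claim that something is new, unique, unknown or untested is made for them only; others in the source may bear on it.

Of the compounds shown here, two with a shared core have been measured in a physicochemical assay for lipophilicity, read by LC-MS, in phosphate buffer, measured as octanol-water partition, with a stated time of 30 min, at pH 7.4, tested at 200 mM; on this read-out higher numbers stand for higher lipophilicity and lower numbers for lower lipophilicity. Compound 1, `Cc1ccc(Oc2ccc3nc(COc4cccc(C(=O)O)c4)n(C)c3n2)cc1C`, gives 2.2 in this assay. Compound 2, `Cn1c(COc2cccc(C(=O)O)c2)nc2ccc(Oc3ccccn3)cc21`, gives 0.4 in this assay; this is the lowest of the two numbers, and the reading for compound 1 lies higher by a margin that is beyond the usual scatter of repeated measurements. Compound 3, `Cn1c(COc2cccc(C(=O)O)c2)nc2ccc(Oc3ccc(Cl)cn3)cc21`, has not yet been measured. It differs from compound 2 in one place: chloro in place of hydrogen on an aromatic carbon two atoms from the ring nitrogen. Among the compounds with values here, no measured pair in this set shows the same exchange, so the size of its effect is not known from these data. An upward step of moderate size is expected for the change a number 0.70 log units higher from compound 2 to compound 3 (beyond the scatter). On that basis compound 3 is estimated at 1.1 in this assay, with a range from 0.6 to 1.6.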

Compound 3, distribution coefficient: 1.2
The estimate for compound 3 lay 0.10 log units below the measured number; measured number inside the range.
By their numbers in this assay, from the lowest: compound 2; then compound 3; then compound 1.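

In this assay the exchange of pyridin-2-yl for 5-chloropyridin-2-yl gives a number 0.80 log units higher from compound 2 to compound 3 (beyond the scatter) and so provides the first measured size for any change at this position. It shows that a single chloro on this aromatic carbon, two atoms from the ring nitrogen and para to a large group, is enough to move the reading beyond the usual scatter, with one heavy atom entering and no hydrogen-bond donors or acceptors. Nothing measured here accounts for the size of this step.

On these data alone, whether fluoro, methyl, methoxy or an amine on the same carbon would give a step of similar size remains open. So does whether chloro would give the same step on another carbon of this ring, or with an amide in place of the carboxylic acid.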